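Trifluoromethylphenyl for Chlorophenyl on the Piperazine Nitrogen

This account rests on a few compounds, and the source may have more. Where it says the series, first, only, none or still open, it means among the compounds named here.

Measured compounds:
compound 1 `CCCc1nc(-c2ccccc2)c(CNCCN2CCN(c3ccc(Cl)cc3)CC2)o1`, 2820 nM
compound 2 `CCCc1nc(-c2ccccc2)c(CNCCCN2CCN(c3ccc(C(F)(F)F)cc3)CC2)o1`, 7250 nM
compound 3 `CCCc1nc(-c2ccccc2)c(CNCCCN2CCN(c3ccc(Cl)cc3)CC2)o1`, 1310 nM

Of the compounds shown here, three have been measured in an assay on HEK293 cells for inhibition of Voltage-dependent T-type calcium channel subunit alpha-1G (Homo sapiens), read by patch clamp; on this read-out higher numbers stand for weaker inhibition and lower numbers for stronger inhibition. Compound 1 stands second highest of the three numbers: compound 3 lies nearest, with a lower number, and compound 2 lies furthest, with a higher number. Among the compounds with values here, the one single-change step among them, a 5.5-fold lower number from compound 2 to compound 3 (0.74 log units; beyond the scatter), was brought about by chloro in place of trifluoromethyl on an aromatic carbon.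

The next compound, compound 4 `CCCc1nc(-c2ccccc2)c(CNCCN2CCN(c3ccccc3C(F)(F)F)CC2)o1`, is derived from compound 1 by a change at one place: 2-(trifluoromethyl)phenyl in place of 4-chlorophenyl on an amine nitrogen in a ring. The step from compound 2 to compound 3 bears on this change in its reverse direction, since here trifluoromethyl enters and chloro leaves; the group, however, sits at a different place on the ring, so the bearing is only partial. On this basis a higher number than for compound 1 is expected, of roughly the size of the known step, and the estimate for compound 4 is 7000 nM, with a range from 2500 nM to 20000 nM, which means an expected step of a 2.5-fold higher number from compound 1 to compound 4 (0.39 log units; beyond the scatter).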

Compound 4, half-maximal inhibitory concentration: 2100 nM
Compound 4: middle estimate off by 3.3-fold (0.52 log units), on the high side; measured number outside the range, below it.
By their numbers in this assay, from the lowest: compounds 3, 4 and 1 (each within the scatter of the next, the first and the last beyond it); then compound 2.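

In this assay, 2-(trifluoromethyl)phenyl on the ring amine nitrogen gives a 1.3-fold lower number from compound 1 to compound 4 (0.13 log units; within the scatter), so this larger group leaves the number within the scatter of that for 4-chlorophenyl. This differs from a 5.5-fold lower number from compound 2 to compound 3 (0.74 log units; beyond the scatter), where the trifluoromethyl compound has the higher number, so the earlier step does not carry over to this change; the two pairs, however, differ in where the trifluoromethyl sits and in the rest of the molecule. Nothing measured here accounts for the difference between the two steps.

From the compounds shown here alone, whether the position of the trifluoromethyl or the rest of the molecule separates the two steps remains open, and 4-(trifluoromethyl)phenyl on the core of compound 1 would bear on that question. Going by these compounds, how 2-chlorophenyl or 2-methoxyphenyl would read at this place also remains open.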